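This account rests on a few compounds, and the source may have more. Where it says the series, first, only, none or still open, it means among the compounds named here.

Compound 1 `COc1cc(-n2ncnc2-c2ccc(C)cc2)cc(OC)c1OC` — 300 nM
Compound 2 `COc1cc(-c2ncnn2-c2ccc(Cl)cc2Cl)cc(OC)c1OC` — > 10000 nM
Compound 3 `COc1cc(-c2ncnn2-c2ccc(F)cc2)cc(OC)c1OC` — > 10000 nM

Among the compounds with values here, in a functional assay on Jurkat cells (Homo sapiens) for antiproliferative activity, read by MTT assay, with a stated time of 72 h (a lower number here means a stronger inhibitor, a higher number a weaker inhibitor), compound 1 gives 300 nM, the only number among the three values shown. For compound 2 the assay reports a limit, > 10000 nM. For compound 3 it likewise reports a limit, > 10000 nM. Within the data shown here, the one measured step, a step that the two limits leave unreadable from compound 2 to compound 3, is therefore unreadable, as both ends sit at the limit of > 10000 nM in this assay, at which 2 of the 3 values shown sit.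

Compound 4 `CCOc1ccc(-c2ncnn2-c2cc(OC)c(OC)c(OC)c2)cc1` differs from compound 1 by ethoxy in place of methyl on an aromatic carbon. No measured step touches this change, and the single step shown gives no size to lean on. Compound 4 is therefore expected to stay near compound 1, with a step of no change at the digits printed from compound 1 to compound 4 (within the scatter). Compound 4 is estimated at 300 nM, within 100 nM to 1000 nM.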

Compound 4, half-maximal inhibitory concentration: 5 nM
Beside the measured number, compound 4's estimate is 60-fold (1.78 log units) above it; measured number below the stated range.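

In this assay, ethoxy in place of methyl on the aromatic carbon para to a large group gives a 60-fold lower number from compound 1 to compound 4 (1.78 log units; beyond the scatter), so this position responds strongly to the group it carries. Within the data shown here, this is the first step of readable size, since the earlier step could not be read. Nothing shown gives a cause for its size.

Whether the oxygen or the added chain length accounts for the step remains open, and an ethyl group would separate the two. On these data alone, how a longer chain such as propoxy or an amine would fare at this position also remains open.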